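The compounds below may be only part of what the source reports. "The series", "measured", "known", "first", "only" and "open" are said of these compounds alone.

In a functional assay on MCF7 cells (Homo sapiens) for inhibition, read by MTT assay, with a stated time of 72 h (a lower number here means a stronger inhibitor, a higher number a weaker inhibitor), compound 1 `Cc1cc(Nc2ccn(Cc3cccc4ccccc34)n2)n2nc(SCc3ccc(Br)cc3)nc2n1` gives 4310 nM, compound 2 `Cc1cc(Nc2ccn(Cc3ccccc3)n2)n2nc(SCc3ccc(Br)cc3)nc2n1` gives 15800 nM and compound 3 `Cc1cc(Nc2cc(-c3ccccc3)[nH]n2)n2nc(SCc3ccc(Br)cc3)nc2n1` gives 2720 nM. Compound 3 thus sits within the scatter of compound 1 and beyond the scatter from compound 2. Compound 4 `Cc1cc(Nc2cc(-c3ccccc3)[nH]n2)n2nc(SCc3nc4ccccc4[nH]3)nc2n1` differs from compound 3 in one place: 1H-benzimidazol-2-yl in place of 4-bromophenyl on a saturated chain carbon bound to a sulfur. Among the compounds with values here, no measured step covers this place. Within the data shown here, the only step, a 3.7-fold higher number from compound 1 to compound 2 (0.56 log units; beyond the scatter), is modest, lies on a saturated chain carbon bound to an aromatic nitrogen, and bears only loosely on this change. No step beyond the scatter is expected in this assay, the estimated step being a 1.7-fold higher number from compound 3 to compound 4 (0.22 log units; within the scatter). For compound 4 the estimated value is 4500 nM, with an expected range of 1300 nM to 16000 nM.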

Compound 4, half-maximal inhibitory concentration: 2730 nM
The estimate for compound 4 lay 1.6-fold (0.22 log units) above the measured number; the measured number falls inside the stated range.
By their numbers in this assay, from the lowest: compounds 3, 4 and 1 (each within the scatter of the next); then compound 2.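

In this assay, within the data shown here, 1H-benzimidazol-2-yl in place of 4-bromophenyl on a saturated chain carbon bound to a sulfur gives a 1.0-fold higher number from compound 3 to compound 4 (0.00 log units; within the scatter) as the first reading at this place. The place thus accepts a group with a hydrogen-bond donor and acceptor and without bromine, with no step beyond the scatter. No measurement at hand explains this result.

Going by these compounds, whether an amine, a carboxylic acid or a longer chain would also stay within the scatter at this place remains open. So does whether this exchange gives the same step on compound 1.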